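A few compounds are considered here, and "the series" means these few. Any claim that something is new, unique, unknown or untested is made for them only; others in the source may bear on it.

Compound 3 `CSc1nc(NCc2ccccc2)c2cccnc2n1` gives the highest number of the three measured compounds in a functional assay on HT-29 cells (Homo sapiens) for cytotoxicity, read by MTT assay, with a stated time of 72 h (a higher number here means a weaker inhibitor of growth, a lower number a stronger inhibitor of growth), at 87100 nM. Compound 1 `CSc1ccc(CNc2nc(SC)nc3ncccc23)cc1` gives 4320 nM and compound 2 `[SeH]c1nc(NCc2ccccc2)c2cccnc2n1` gives 6350 nM; the steps of a 20-fold higher number from compound 1 to compound 3 (1.30 log units; beyond the scatter) and a 14-fold higher number from compound 2 to compound 3 (1.14 log units; beyond the scatter) are both large. Compound 4 `CSc1nc(NCCCCCO)c2cccnc2n1` differs from compound 3 by 4-hydroxybutyl in place of phenyl on a saturated chain carbon bound to a nitrogen on an aromatic ring. Within the data shown here, the two measured steps alter the group on the aromatic carbon, not the chain carbon bound to the ring nitrogen, so no measured step speaks to this change directly. Without guidance, a modest change in either direction or none beyond the scatter is plausible, and compound 4 is expected near compound 3, with a 1.1-fold higher number from compound 3 to compound 4 (0.06 log units; within the scatter). Compound 4 is estimated at 100000 nM, within 20000 nM to 400000 nM.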

Compound 4, concentration for 50% growth inhibition: 63900 nM
For compound 4 the middle estimate is 1.6-fold (0.19 log units) above the measured one; the range from low to high includes it.
By their numbers in this assay, from the lowest: compounds 1 and 2 (each within the scatter of the next); then compounds 4 and 3 (each within the scatter of the next).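

In this assay, among these compounds, the first step at this place, a saturated chain carbon bound to a nitrogen on an aromatic ring, is a 1.4-fold lower number from compound 3 to compound 4 (0.13 log units; within the scatter) and it lies within the scatter. For this pair, an aromatic ring can give way to 4-hydroxybutyl, with no ring and a hydrogen-bond donor and acceptor, without a reading beyond the scatter. No evidence here bears on this result. Open, from the compounds shown here alone, is whether an amine, a carboxylic acid or a longer chain at this place would do the same. Also open, going by these compounds, is whether 4-hydroxybutyl would behave alike on the cores of compound 1 or compound 2.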